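A Methyl Added to the Furan-2-yl Group of Compound 3

This account rests on a few compounds, and the source may have more. Where it says the series, first, only, none or still open, it means among the compounds named here.

Compound 3 `Clc1ccc(-c2cc(-c3ccoc3)cc(-c3ccco3)n2)s1` gives 9.6% in an assay on isolated protein for inhibition of DNA topoisomerase 1 (Homo sapiens), with a stated time of 30 min, tested at 100 uM (a lower number here means less inhibition, a higher number more inhibition at the concentration tested (going by the name of the read-out)), the largest of the three numbers shown, although it lies within the scatter of compound 2 `Cc1ccsc1-c1cc(-c2ccoc2)cc(-c2ccco2)n1`, which gives 5.4%, and of compound 1 `Cc1ccsc1-c1cc(-c2ccco2)cc(-c2ccccc2Cl)n1`, which gives 2%. Compound 4 `Cc1ccc(-c2cc(-c3ccoc3)cc(-c3ccc(Cl)s3)n2)o1` differs from compound 3 by methyl in place of hydrogen on an aromatic carbon; read one bond further out, furan-2-yl becomes 5-methylfuran-2-yl. Among the compounds with values here, no measured step touches this change: the single step available, a number 4.2 percentage points higher from compound 2 to compound 3 (within the scatter), alters another group and stays within the scatter. Within the data shown here, since every number so far is small and the change is one carbon, compound 4 is expected to stay close to compound 3, with a step of a number 0.4 percentage points higher from compound 3 to compound 4 (within the scatter) expected. Compound 4 is therefore estimated at 10%, between 2% and 22%.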

Compound 4, a percentage reported as inhibition, at one concentration (the size of the read-out at that concentration, not a potency): 13.2%
The estimate for compound 4 lay 3.2 percentage points below the measured number, and the stated range covers the measured number.
By their numbers in this assay, from the lowest: compounds 1, 2, 3 and 4 (each within the scatter of the next, the first and the last beyond it).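

Methyl in place of hydrogen on this aromatic carbon, next to the ring oxygen, gives a number 3.6 percentage points higher from compound 3 to compound 4 (within the scatter) in this assay, the first measured change at the furan-2-yl group. At this position, then, the single added carbon stays within what repeated measurements would scatter. No measurement of any property bears on this result. From the compounds shown here alone, whether an amine, a carboxylic acid or a longer chain at this position would move the number beyond the scatter stays open. So does whether methyl behaves alike when 3-methylthiophen-2-yl replaces 5-chlorothiophen-2-yl.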